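Dropping the Chlorine: From Compound 1 to Compound 4

The source may report more compounds than this note shows. Statements on the series, on what has been measured and on what is new or still open speak of the compounds shown alone.

Three compounds have been measured in a functional assay on HT-29 cells (Homo sapiens) for inhibition; on this read-out lower numbers stand for stronger inhibition of growth and higher numbers for weaker inhibition of growth:
Compound 1 `COc1cc(/C=C/C(=O)c2cccc(-n3cc(-c4ccc(Cl)cc4)[nH]c3=O)c2)cc(OC)c1OC` gives 2000 nM.
Compound 2 `COc1cc(/C=C/C(=O)c2cccc(-n3cc(-c4ccccc4)[nH]c3=O)c2)ccc1O` gives 3770 nM.
Compound 3 `O=C(/C=C/c1cccc(O)c1)c1cccc(-n2cc(-c3ccccc3)[nH]c2=O)c1` gives 3330 nM.

Compound 1 shows the smallest of the three numbers, but its gaps to compound 3 and to compound 2 both lie within the usual scatter, so the three cannot be ranked. Compound 4 `COc1cc(/C=C/C(=O)c2cccc(-n3cc(-c4ccccc4)[nH]c3=O)c2)cc(OC)c1OC` differs from compound 1 by hydrogen in place of chloro on an aromatic carbon. Within the data shown here, the only single-point step available, a 1.1-fold lower number from compound 2 to compound 3 (0.05 log units; within the scatter), concerns the other end of the molecule and stayed within the scatter; no measured pair isolates the loss of chloro. Compounds 2 and 3 also carry a plain phenyl and sit close to compound 1. Compound 4 is therefore expected to move little, a 1.5-fold higher number from compound 1 to compound 4 (0.18 log units; within the scatter). Compound 4 is estimated at 3000 nM, between 1200 nM and 8000 nM.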

Compound 4, concentration for 50% growth inhibition: 660 nM
Compound 4: the middle estimate sits 4.5-fold (0.66 log units) above what was measured, and the stated range ends above it.
By their numbers in this assay, from the lowest: compound 4; then compounds 1, 3 and 2 (each within the scatter of the next).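

Among these compounds, replacing chloro with hydrogen on this aromatic carbon, para to a large group, brings a 3.0-fold lower number from compound 1 to compound 4 (0.48 log units; beyond the scatter), the first step in this set that lies beyond the scatter. It shows that this position does affect growth inhibition, and that the plain phenyl gives stronger inhibition than the 4-chlorophenyl in this pair. No measurement here explains the difference. Among the compounds shown here, with only this one pair, it remains open how fluoro, methyl or an amine at this position would compare. Also open, from the compounds shown here alone, is whether the same step would appear with the other end of the molecule found in compound 2.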